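Swapping the anilide ring: from compound 1 to compound 3

A few compounds are considered here, and "the series" means these few. Any claim that something is new, unique, unknown or untested is made for them only; others in the source may bear on it.

Compound 1 `CN(c1cccc2c1CN(c1nc(Nc3ccc(Cl)c(C(F)(F)F)c3)ncc1C(F)(F)F)C2)S(C)(=O)=O` and compound 2 `COc1cc(N2CCN(C(C)=O)CC2)ccc1Nc1ncc(C(F)(F)F)c(N2Cc3cccc(N(C)S(C)(=O)=O)c3C2)n1` share a core and were tested in a functional assay on A549 cells (Homo sapiens) for antiproliferative activity, read by spectrophotometry, with a stated time of 2 days; on this read-out higher numbers stand for weaker inhibition of growth and lower numbers for stronger inhibition of growth. In this assay compound 1 gives 15200 nM, the highest of the two numbers, while compound 2 gives 3300 nM, a lower number lying beyond the usual scatter. Among the compounds with values here, no single-point step joins these two compounds, so only their two values can be read side by side.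

Compound 3 `COc1cc(Nc2ncc(C(F)(F)F)c(N3Cc4cccc(N(C)S(C)(=O)=O)c4C3)n2)c(OC)cc1Cl` has not yet been measured. It differs from compound 1 in one place: 4-chloro-2,5-dimethoxyphenyl in place of 4-chloro-3-(trifluoromethyl)phenyl on a nitrogen on an aromatic ring. The ring that enters carries two hydrogen-bond acceptors where the ring that leaves carried none.

Within the data shown here, with no measured step of this kind to lean on, a modest move toward stronger growth inhibition is expected for compound 3, as a 1.9-fold lower number from compound 1 to compound 3 (0.28 log units; within the scatter). Compound 3 is accordingly estimated at 8000 nM, with a range from 2500 nM to 25000 nM.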

Compound 3, concentration for 50% growth inhibition: 7300 nM
Compound 3: middle estimate off by 1.1-fold (0.04 log units), on the high side, and the stated range covers the measured number.
By their numbers in this assay, from the lowest: compound 2; then compound 3; then compound 1.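

In this assay, 4-chloro-2,5-dimethoxyphenyl in place of 4-chloro-3-(trifluoromethyl)phenyl gives a 2.1-fold lower number from compound 1 to compound 3 (0.32 log units; beyond the scatter) with the rest of the molecule unchanged. Within the data shown here, this is the first direct evidence that the group on this nitrogen affects growth inhibition, although the step is modest. The trifluoromethyl group is lost and two methoxy groups are gained in the same change, so this single step cannot show which of these matters, and no accompanying measurement offers an explanation.

Going by these compounds, it remains open whether a ring carrying only one of the two methoxy groups would keep this step. Also unresolved is how a nitrile or a carboxylic acid on this ring would compare with either ring tested here.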